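This account rests on a few compounds, and the source may have more. Where it says the series, first, only, none or still open, it means among the compounds named here.

The measured compounds:
compound 1, `CC(C)(C)c1cn(C[C@H](O)[C@H]2OC(=O)C(OCc3ccccc3)=C2OCc2ccccc2)nn1`, 730 nM;
compound 2, `O=C1O/C(=C\Cn2cc(-c3cc(F)cc(F)c3)nn2)C(OCc2ccccc2)=C1OCc1ccccc1`, > 100000 nM;
compound 3, `Cc1ccc(-c2cn(C/C=C3\OC(=O)C(OCc4ccccc4)=C3OCc3ccccc3)nn2)cc1`, > 100000 nM.

Within the data shown here, in a functional assay on MCF7 cells (Homo sapiens) for antiproliferative activity, read by MTT assay, with a stated time of 72 h (on this read-out higher numbers stand for weaker inhibition and lower numbers for stronger inhibition), compound 1 gives 730 nM, the only value here that is an actual number. For compound 2 the value > 100000 nM is a limit of the assay, not a number. For compound 3 the value > 100000 nM is likewise a limit. Among the measured compounds shown here, the single step between measured compounds, a step that the two limits leave unreadable from compound 2 to compound 3, cannot be read, because both of its ends sit at the limit of > 100000 nM in this assay, at which 2 of the 3 values shown sit.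

Compound 4, `C[Si](C)(C)c1cn(C[C@H](O)[C@H]2OC(=O)C(OCc3ccccc3)=C2OCc2ccccc2)nn1`, differs from compound 1 by a group of 4 heavy atoms (3 carbon, 1 silicon; no ring) in place of a group of 4 heavy atoms (4 carbon; no ring), on an aromatic carbon. For the measured compounds named here, no measured step touches a swap of this kind on the five-membered aromatic ring with 3 nitrogen, and the one step that exists is unreadable. Going by the values given here, compound 1 gives 730 nM in this assay, and nothing among the measured steps argues for a move beyond the usual scatter. Compound 4 is therefore expected at 700 nM, in a range from 250 nM to 2500 nM. Compound 4 is thus expected to show a 1.0-fold lower number from compound 1 to compound 4 (0.02 log units; within the scatter).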

Compound 4, half-maximal inhibitory concentration: 12100 nM
Beside the measured number, compound 4's estimate is 17-fold (1.24 log units) below it, outside the stated range (above it).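

In this assay, putting the group of 3 carbon and 1 silicon in place of tert-butyl gives a 17-fold higher number from compound 1 to compound 4 (1.22 log units; beyond the scatter). Among these compounds, both groups have the same count of heavy atoms and neither has a ring, yet this is the first readable step, and it shows that this aromatic carbon of the five-membered ring with 3 nitrogen does not treat the two groups alike, even though only one carbon has been exchanged for silicon. Nothing shown here explains why the number moves.

Going by these compounds, with only these two groups compared on the core of compound 1, it stays open whether a smaller methyl, a cyclopropyl ring or an aminomethyl group would hold the number of compound 1 or lose more. On these data alone, whether the same step appears in other cell lines also remains unknown.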